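Chloromethyl in Place of Propargyl on the Quaternary Nitrogen

This account rests on a few compounds, and the source may have more. Where it says the series, first, only, none or still open, it means among the compounds named here.

Compound 3 `C#CC[N+](C)(C)CCCC(=O)[O-]` carries a propargyl group on its quaternary nitrogen. In an assay for inhibition of gamma-butyrobetaine dioxygenase (Homo sapiens), read by HPLC, with stated times of 15 min and 30 min (a higher number here means a weaker inhibitor, a lower number a stronger inhibitor), compound 3 gives 1400 nM, the highest of the two numbers reported. Compound 2 `C[N+](C)(CCCC(=O)[O-])C1CCC1` gives 810 nM in this assay, and the step of a 1.7-fold higher number from compound 2 to compound 3 (0.24 log units; within the scatter) lies within the scatter. Compound 1 `CCCC[N+](C)(C)CCCC(=O)[O-]` reaches only a limit of the assay: in this assay compound 1 gives > 1000000 nM (the limit of > 1000000 nM in this assay, at which 1 of the 3 values shown sits). From compound 1 the steps of an at least 1200-fold lower number from compound 1 to compound 2 (3.09 log units; beyond the scatter) and an at least 710-fold lower number from compound 1 to compound 3 (2.85 log units; beyond the scatter) are both large.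

Compound 4 `C[N+](C)(CCl)CCCC(=O)[O-]` differs from compound 3 in one place: chloro in place of ethynyl on a saturated chain carbon bound to an amine nitrogen. The measured step from compound 1 to compound 3 bears most directly on this change, since it also exchanged a group on the same carbon bound to the nitrogen, and it was large. The step between compound 2 and compound 3 shows that two different compact groups on the nitrogen give numbers within the scatter of each other. The entering chloro counts fewer heavy atoms than the departing ethynyl, and a compact group is retained. The expectation for this assay is therefore a step no larger than a modest rise in the number.

For compound 4 the expected value in this assay is estimated at 3000 nM, within a range from 500 nM to 20000 nM. That estimate corresponds to an expected step of a 2.1-fold higher number from compound 3 to compound 4 (0.33 log units; beyond the scatter).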

Compound 4, half-maximal inhibitory concentration: 268000 nM
Estimate against measurement, compound 4: 89-fold (1.95 log units) below, outside the stated range (above it).
By their numbers in this assay, from the lowest: compounds 2 and 3 (each within the scatter of the next); then compound 4. At a limit, above all of these: compound 1.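

The change shows that the group on this saturated chain carbon bound to an amine nitrogen can move the number in this assay by far more than compounds 2 and 3 suggested: a 190-fold higher number from compound 3 to compound 4 (2.28 log units; beyond the scatter) and a 330-fold higher number from compound 2 to compound 4 (2.52 log units; beyond the scatter) are both large. Compounds 2 and 3 had given numbers within the scatter of each other, so they had not shown that an exchange removing so little as ethynyl for chloro could separate compounds this widely, and a lower heavy-atom count in the entering group did not keep compound 4 near them. The step of an at least 3.7-fold lower number from compound 1 to compound 4 (0.57 log units; beyond the scatter) is a bound only and gives no measured size, for compound 1 stands at a limit of the assay: the limit of > 1000000 nM in this assay, at which 1 of the 4 values shown sits.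

The compounds shown leave open whether the rise follows the chlorine itself or the change from propargyl to chloromethyl as a whole, a question that a fluoromethyl, bromomethyl or hydroxymethyl group on the same nitrogen would bear on. They also leave open how a longer chain carrying chlorine, such as chloroethyl or chloropropyl, would read in this assay.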